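A few compounds are considered here, and "the series" means these few. Any claim that something is new, unique, unknown or untested is made for them only; others in the source may bear on it.

Among the compounds with values here, in an ADME assay on MT4 cells (Homo sapiens) for cytotoxicity, read by MTT assay (a lower number here means that less compound is tolerated, a higher number that more compound is tolerated), compound 3 `Cc1ccc(N(C(=O)c2cc(F)ccc2F)C(=S)OCCN2C(=O)c3ccccc3C2=O)cc1` gives 62000 nM, the only true number so far. Compound 1 `Cc1ccc(N(C(=O)c2ccccc2C)C(=S)OCCN2C(=O)c3ccccc3C2=O)cc1` reads > 100000 nM, which is a limit of the assay and not a number. Compound 2 `Cc1ccc(N(C(=O)c2cccc(C)c2)C(=S)OCCN2C(=O)c3ccccc3C2=O)cc1` reads > 100000 nM, which is also a limit. Compound 4 `Cc1ccc(N(C(=O)c2c(Cl)cccc2Cl)C(=S)OCCN2C(=O)c3ccccc3C2=O)cc1` differs from compound 3 in one group: 2,6-dichlorophenyl in place of 2,5-difluorophenyl on a carbonyl carbon. That is, it carries 2,6-dichlorophenyl in place of 2,5-difluorophenyl on a carbonyl carbon. The measured steps at this same place are an at least 1.6-fold lower number from compound 1 to compound 3 (0.20 log units; that floor lies within the scatter) and an at least 1.6-fold lower number from compound 2 to compound 3 (0.20 log units; that floor lies within the scatter). Both lie within the scatter, so neither gives firm guidance on size or direction. Only a small step, not beyond the scatter, is therefore expected, a 1.1-fold higher number from compound 3 to compound 4 (0.05 log units; within the scatter). Compound 4 is estimated at 70000 nM, with an expected range of 30000 nM to 130000 nM.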

Compound 4, half-maximal cytotoxic concentration: 22000 nM
For compound 4 the middle estimate is 3.2-fold (0.50 log units) above the measured one; the whole stated range lies above it.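

In this assay, the group on this carbonyl carbon now gives a step beyond the scatter, a 2.8-fold lower number from compound 3 to compound 4 (0.45 log units; beyond the scatter), so changing it can alter how much compound the cells tolerate. The gaps to the two methylphenyl compounds are also beyond the scatter: an at least 4.5-fold lower number from compound 2 to compound 4 (0.65 log units; beyond the scatter) and an at least 4.5-fold lower number from compound 1 to compound 4 (0.65 log units; beyond the scatter). Their true sizes stay unknown because compound 1 and compound 2 both sit at a limit: the limit of > 100000 nM in this assay, at which 2 of the 4 values shown sit.

Whether the chlorine atoms themselves or their placement matters remains open, as 2,6-dichlorophenyl is the only chlorine-bearing group shown. As far as these compounds go, the effect of an amine or a carboxylic acid on this ring is also open.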